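The source may hold more compounds than are shown below. What is called first, only, known or untested is meant among the compounds shown, and "the series" means these compounds.

Working notes on the series. Compound 2 `Cc1cc(N(C)C)nc(N[C@H]2CC[C@@H](NC(=O)c3ccc(Cl)cc3)CC2)n1` carries a 4-chlorophenyl amide on the shared core. In a functional assay on HEK293 cells for antagonist activity at melanin-concentrating hormone receptor 1 (Homo sapiens), read by FLIPR and calcium flux (a higher number here means a weaker inhibitor, a lower number a stronger inhibitor), compound 2 gives 16 nM. Among the three compounds measured it stands second highest: compound 3 `Cc1cc(N(C)C)nc(N[C@H]2CC[C@@H](NC(=O)c3cccc(Cl)c3)CC2)n1`, with a 3-chlorophenyl amide on the same core, gives 6.5 nM, while compound 1 `CNc1nc(N[C@H]2CC[C@@H](CNC(=O)c3cc(C(F)(F)F)cc(C(F)(F)F)c3)CC2)ncc1C`, built on a different core with two trifluoromethyl groups on the amide ring, gives 200 nM. Within the data shown here, the only single-point step on record, a 2.5-fold lower number from compound 2 to compound 3 (0.39 log units; beyond the scatter), changes where the chlorine sits on the ring and is modest in size.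

Compound 4 `Cc1cc(N(C)C)nc(N[C@H]2CC[C@@H](NC(=O)c3ccc(OC(F)(F)F)cc3)CC2)n1` differs from compound 2 by trifluoromethoxy in place of chloro on an aromatic carbon. Among the measured compounds shown here, no measured step exchanges one substituent for another at a single aromatic carbon, so the step from compound 2 to compound 3 bears only loosely on this change, and the gap between compound 1 and compound 2 combines a change of core with a change of amide and cannot be split. The data therefore offer no direction for the exchange, and the step from compound 2 to compound 4 is expected to be a 1.6-fold higher number from compound 2 to compound 4 (0.19 log units; within the scatter), within the scatter. Compound 4 is expected to give 25 nM in this assay, with a range from 8 nM to 80 nM.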

Compound 4, half-maximal inhibitory concentration: 230 nM
Estimate against measurement, compound 4: 9.2-fold (0.96 log units) below; measured number above the stated range.
By their numbers in this assay, from the lowest: compound 3; then compound 2; then compounds 1 and 4 (each within the scatter of the next).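

In this assay the exchange at this carbon proves far from neutral: there is a 14-fold higher number from compound 2 to compound 4 (1.16 log units; beyond the scatter) when trifluoromethoxy, with its 5 heavy atoms, replaces chloro, with its 1, on an aromatic carbon para to a large group. Among these compounds, the only earlier step on this ring, a 2.5-fold lower number from compound 2 to compound 3 (0.39 log units; beyond the scatter), moves the chlorine and is modest, so it gave no sign that changing the group itself could cost this much, and the two steps run in opposite directions. No measurement shown accounts for the large rise, and its cause stays unassigned.

Whether the rise belongs to trifluoromethoxy in particular or would also follow other groups at this carbon stays open, as the compounds shown hold only chloro and trifluoromethoxy there and nothing such as methoxy, methyl or a nitrile. Also open, on these data alone, is how trifluoromethoxy would behave on the ring carbon that carries the chlorine in compound 3, since the two changes are seen only separately, each starting from compound 2.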